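The source may hold more compounds than are shown below. What is called first, only, known or untested is meant among the compounds shown, and "the series" means these compounds.

Compound 3, `COc1ccc(-c2cn(-c3cccc(C(=O)/C=C/c4ccc(O)c(OC)c4)c3)c(=O)[nH]2)cc1`, is examined in a functional assay on PC-3 cells (Homo sapiens) for inhibition (on this read-out lower numbers stand for stronger inhibition of growth and higher numbers for weaker inhibition of growth), where it gives 3050 nM. Among the compounds with a reported number it holds the lowest figure, but compound 2, `COc1cc(/C=C/C(=O)c2cccc(-n3cc(-c4ccccc4)[nH]c3=O)c2)cc(OC)c1OC`, gives 3260 nM, and the two figures lie within the usual scatter of each other, so neither can be told apart from the other. Compound 1, `COc1cc(/C=C/C(=O)c2cccc(-n3cc(-c4ccc(Cl)cc4)[nH]c3=O)c2)cc(OC)c1OC`, is reported as "not active" (no number reported) in this assay, without a number. The step to compound 4, `COc1ccc(-c2cn(-c3cccc(C(=O)/C=C/c4cc(OC)c(OC)c(OC)c4)c3)c(=O)[nH]2)cc1`, replaces one of the outer rings: 3,4,5-trimethoxyphenyl in place of 4-hydroxy-3-methoxyphenyl on a double-bonded chain carbon bound to a double-bonded chain carbon. The same 3,4,5-trimethoxyphenyl ring is carried by compound 2 and compound 1, with the first giving a number close to that of compound 3 and the second giving none. Going by the values given here, no directly comparable measured pair exists for this exchange, so the expectation rests on those two neighbours. Compound 4 is therefore expected to give roughly 4500 nM in this assay, with a range from 1500 nM to 15000 nM, and the estimated step of a 1.5-fold higher number from compound 3 to compound 4 (0.17 log units; within the scatter) is expected to be small, possibly none beyond the scatter, with some chance of weaker inhibition.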

Compound 4, concentration for 50% growth inhibition: 6220 nM
The estimate for compound 4 lay 1.4-fold (0.14 log units) below the measured number; measured number inside the range.
By their numbers in this assay, from the lowest: compounds 3, 2 and 4 (each within the scatter of the next, the first and the last beyond it).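

In this assay, going by these compounds alone, the exchange of 4-hydroxy-3-methoxyphenyl for 3,4,5-trimethoxyphenyl on a double-bonded chain carbon bound to a double-bonded chain carbon gives a 2.0-fold higher number from compound 3 to compound 4 (0.31 log units; beyond the scatter), the first step at this place to show a modest loss of growth inhibition. The second exchange, methoxy in place of hydrogen on an aromatic carbon, gives a 1.9-fold higher number from compound 2 to compound 4 (0.28 log units; within the scatter), so it cannot be told apart from no change. No measurement shown here accounts for either step.

The compounds shown leave open whether the loss at this place goes with the hydroxy group leaving or with the added methoxy groups, as both change in one exchange. On these data alone, how a ring carrying an amine or a carboxylic acid at this place would stand in this assay also remains open.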